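Pyridin-4-yl amide in an N-phenylpyrazole series

A few compounds are considered here, and "the series" means these few. Any claim that something is new, unique, unknown or untested is made for them only; others in the source may bear on it.

Compound 1: `O=C(Nc1cc(-c2ccccc2)nn1-c1ccccc1)c1ccc(C(F)(F)F)cc1`, 990 nM
Compound 2: `NC(=O)c1ccc(C(=O)Nc2cc(-c3ccccc3)nn2-c2ccccc2)cc1`, > 10000 nM
Compound 3: `O=C(Nc1cc(-c2ccccc2)nn1-c1ccccc1)c1ccc(Cl)c(Cl)c1`, 160 nM

In an assay on HEK293 cells for displacement of a labelled ligand from metabotropic glutamate receptor 5 (Rattus norvegicus) (on this read-out higher numbers stand for weaker inhibition and lower numbers for stronger inhibition), compound 3 gives the lowest number of the two that are reported as numbers, and compound 1 stands nearest to it with a 6.2-fold lower number from compound 1 to compound 3 (0.79 log units; beyond the scatter). For compound 2 the assay reports only a limit, (the limit of > 10000 nM in this assay, at which 1 of the 3 values shown sits), and not a number. Compound 4 is `O=C(Nc1cc(-c2ccccc2)nn1-c1ccccc1)c1ccncc1`, not yet measured in this assay. It differs from compound 3 in one place: pyridin-4-yl in place of 3,4-dichlorophenyl on a carbonyl carbon.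

Going by the values given here, two measured steps bear on this change. The step of an at least 10-fold higher number from compound 1 to compound 2 (1.00 log units; beyond the scatter) shows that replacing trifluoromethyl with carbamoyl on the same aromatic carbon costs potency. The step of an at least 62-fold lower number from compound 2 to compound 3 (1.79 log units; beyond the scatter) shows the same pattern from the other side. Both steps say that the 3,4-dichlorophenyl amide is the most favourable of the three aryl groups, and the entering pyridin-4-yl brings one hydrogen-bond acceptor where the leaving group has none. Compound 4 is therefore expected to give a weaker result than compound 3, with an estimated step of a 25-fold higher number from compound 3 to compound 4 (1.40 log units; beyond the scatter). The expected value for compound 4 in this assay is 4000 nM, within an estimated range from 800 nM to 20000 nM.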

Compound 4, inhibition constant: > 10000 nM
Compound 4: a limit, no number; the forecaster's own chance of this, stated with the estimate: 30%; middle value at least 2.5-fold (0.39 log units) from the limit.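

In this assay compound 4 gives only a limit and no number: the limit of > 10000 nM in this assay, at which 2 of the 4 values shown sit.

The change is large measured from the 3,4-dichlorophenyl amide, an at least 62-fold higher number from compound 3 to compound 4 (1.79 log units; beyond the scatter), and at least modest measured from the 4-(trifluoromethyl)phenyl amide, an at least 10-fold higher number from compound 1 to compound 4 (1.00 log units; beyond the scatter). Before this result, 4-carbamoylphenyl was the only group on this carbonyl carbon to reach the limit, and pyridin-4-yl now shows that this outcome is not confined to that group, since a six-membered aromatic ring with 1 hetero atom and no further substituent reaches it too. The step between compound 2 and compound 4 cannot be read, as both values are limits, so the two groups cannot be ranked against each other.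

On these data alone, it remains open how far above the limit compound 2 and compound 4 lie, and whether the ring nitrogen of pyridin-4-yl or the loss of the two chlorine atoms accounts for the change. As far as these compounds go, a plain phenyl, a 4-chlorophenyl or a chloropyridinyl group on this carbonyl carbon would separate those two changes, and how any of them would read here is unknown.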